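The source may report more compounds than this note shows. Statements on the series, on what has been measured and on what is new or still open speak of the compounds shown alone.

Measured in a functional assay on HCT-15 cells (Homo sapiens) for antiproliferative activity; on this read-out higher numbers stand for weaker inhibition of growth and lower numbers for stronger inhibition of growth:
- Compound 1 `c1ccc(-c2cc(-c3ccsc3)cc(-c3ccccn3)n2)nc1`: 0.29 ug/mL
- Compound 2 `c1ccc(-c2cc(-c3ccccn3)nc(-c3ccccn3)c2)cc1`: 0.37 ug/mL
- Compound 3 `c1ccc(-c2cc(-c3ccsc3)cc(-c3cccnc3)n2)nc1`: > 100 ug/mL, a limit of the assay

Among the compounds with values here, compound 1 stands level with compound 2, as a 1.3-fold higher number from compound 1 to compound 2 (0.11 log units; within the scatter) shows, and these two hold the only exact numbers. Compound 4 `c1ccc(-c2cc(-c3ccco3)cc(-c3ccccn3)n2)nc1` has furan-2-yl in place of thiophen-3-yl on an aromatic carbon, opposite the ring nitrogen (furan-2-yl in place of thiophen-3-yl on an aromatic carbon). The swap at this same place, a 1.3-fold higher number from compound 1 to compound 2 (0.11 log units; within the scatter), made little difference. The large step, an at least 340-fold higher number from compound 1 to compound 3 (2.53 log units; beyond the scatter), came from a change to a pyridin-2-yl group, which compound 4 keeps. So no step beyond the scatter is expected in this assay. The expected change is a 1.4-fold higher number from compound 1 to compound 4 (0.14 log units; within the scatter). For compound 4 the estimated value is 0.4 ug/mL, with an expected range from 0.12 ug/mL to 1.6 ug/mL.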

Compound 4, concentration for 50% growth inhibition: 0.1 ug/mL
Estimate against measurement, compound 4: 4.0-fold (0.60 log units) above; measured number below the stated range.
By their numbers in this assay, from the lowest: compound 4; then compounds 1 and 2 (each within the scatter of the next). At a limit, above all of these: compound 3.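

In this assay furan-2-yl in place of thiophen-3-yl opposite the ring nitrogen gives a 2.9-fold lower number from compound 1 to compound 4 (0.46 log units; beyond the scatter) and furan-2-yl in place of phenyl gives a 3.7-fold lower number from compound 2 to compound 4 (0.57 log units; beyond the scatter). So this place, where the swap between compound 1 and compound 2 stayed within the scatter, does respond to the ring set there, though modestly. Nothing shown accounts for why furan-2-yl stands apart from the other two rings. Still open, as far as these compounds go, is whether this gain extends to related rings such as furan-3-yl or thiophen-2-yl. Also open, from the compounds shown here alone, is how an amine or a longer chain would fare at this place.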